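Replacing pyridin-4-yl with 3-phenylphenyl on the shared core

The compounds below may be only part of what the source reports. "The series", "measured", "known", "first", "only" and "open" are said of these compounds alone.

Three compounds built on one shared core have been run through an ADME assay on BJ cells (Homo sapiens) for cytotoxicity, read by CellTiter-Glo and resazurin assay, with a stated time of 72 h; a higher number here means that more compound is needed for the effect, a lower number that less compound is needed. Compound 1 `CC(C)N(Cc1cccc(OCCCCCC(=O)O)c1)C(=O)c1ccc(-c2cccc(N(C)C)c2)cc1` carries 3-(dimethylamino)phenyl, and in this assay compound 1 gives > 26000 nM, which is a limit of the assay rather than a number. Compound 2 `CC(C)N(Cc1cccc(OCCCCCC(=O)O)c1)C(=O)c1ccc(-c2cccc3ccccc23)cc1` carries naphthalen-1-yl in the same place, and compound 2 gives < 1.3 nM, again a limit. Compound 3 `CC(C)N(Cc1cccc(OCCCCCC(=O)O)c1)C(=O)c1ccc(-c2ccncc2)cc1` carries pyridin-4-yl, and compound 3 gives > 26000 nM, also a limit. Compound 3 thus stands at the upper edge of what this assay reports, as the limit of > 26000 nM in this assay, at which 2 of the 3 values shown sit, shows. The step of an at least 20000-fold higher number from compound 2 to compound 3 (4.30 log units; beyond the scatter) is large, and an at least 20000-fold lower number from compound 1 to compound 2 (4.30 log units; beyond the scatter) is large in the other direction, both resting on (the limit of < 1.3 nM in this assay, at which 1 of the 3 values shown sits). The step that the two limits leave unreadable from compound 1 to compound 3 cannot be read.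

Compound 4 `CC(C)N(Cc1cccc(OCCCCCC(=O)O)c1)C(=O)c1ccc(-c2cccc(-c3ccccc3)c2)cc1` differs from compound 3 by 3-phenylphenyl in place of pyridin-4-yl on an aromatic carbon. Within the data shown here, the one measured step that bears on this change is an at least 20000-fold higher number from compound 2 to compound 3 (4.30 log units; beyond the scatter), in which a group made of carbon-only aromatic rings gave way to pyridin-4-yl. Since the entering 3-phenylphenyl again consists of carbon-only aromatic rings, a large move in the opposite direction is expected, an at least 2600-fold lower number from compound 3 to compound 4 (3.41 log units; beyond the scatter). Compound 4 is therefore estimated at 10 nM, within a range from 1 nM to 300 nM.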

Compound 4, half-maximal effective concentration: > 26000 nM
Compound 4: no number, only a limit (the forecaster's own chance of this, stated with the estimate: 30%); at least 2600-fold (3.41 log units) between middle value and limit.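

Among these compounds, compound 4 adds something new: until now the only group at this place that gave a low number in this assay was built of carbon-only aromatic rings, and 3-phenylphenyl is built of such rings too, yet no low number appears. The change from naphthalen-1-yl to 3-phenylphenyl is an at least 20000-fold higher number from compound 2 to compound 4 (4.30 log units; beyond the scatter), so two groups made only of carbon-only aromatic rings now sit at opposite ends of what this assay reports, and having such rings at this place is not enough by itself. Compound 4 joins compound 1 and compound 3 at the upper edge, where each value is a limit and not a number, so the steps among these three cannot be read: the limit of > 26000 nM in this assay, at which 3 of the 4 values shown sit.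

The compounds shown leave open whether the low limit of compound 2 belongs to naphthalen-1-yl alone or would also appear with naphthalen-2-yl or an unsubstituted phenyl at the same place. They also leave open whether compound 2 would keep its low limit if an amine stood in place of the carboxylic acid on the shared core.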